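A few compounds are considered here, and "the series" means these few. Any claim that something is new, unique, unknown or untested is made for them only; others in the source may bear on it.

Measured in an ADME assay on cells (Homo sapiens) for cytotoxicity, read by polymerase chain reaction, with a stated time of 3 days; on this read-out higher numbers stand for lower toxicity in this test and lower numbers for higher toxicity in this test:
compound 1 `Cc1nc(NCCNC(=O)NC(C)(C)C)nc(N[C@@H]2C[C@H](CO)[C@@H](O)[C@H]2O)c1-c1nc2ccccc2s1` gives > 25000 nM, a limit of the assay.
compound 2 `Cc1nc(Nc2ccccc2)nc(N[C@@H]2C[C@H](CO)[C@@H](O)[C@H]2O)c1-c1nc2ccccc2s1` gives > 25000 nM, likewise a limit of the assay.

Compound 2 thus stands at the limit of this assay, where both values shown sit (the limit of > 25000 nM in this assay, at which 2 of the 2 values shown sit). The step that the two limits leave unreadable from compound 1 to compound 2 cannot be read from two limits. Compound 3 `Cc1nc(NCc2nccs2)nc(N[C@@H]2C[C@H](CO)[C@@H](O)[C@H]2O)c1-c1nc2ccccc2s1` differs from compound 2 by (1,3-thiazol-2-yl)methyl in place of phenyl on a nitrogen on an aromatic ring. No measured step bears on this change, since the only step shown is unreadable. For a step that the limit leaves unreadable from compound 2 to compound 3 no step beyond the scatter is expected. Compound 3 is expected to give 30000 nM in this assay, with a range of 10000 nM to 100000 nM, most likely reported again only as a limit.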

Compound 3, half-maximal cytotoxic concentration: 23000 nM
Estimate against measurement, compound 3: 1.3-fold (0.12 log units) above; the measured number falls inside the stated range.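

In this assay, among the compounds shown here, compound 3 gives 23000 nM, the first value in this set that is a number and not a limit of the assay. The readable changes are an at least 1.0-fold lower number from compound 2 to compound 3 (0.03 log units; that floor lies within the scatter) and an at least 1.0-fold lower number from compound 1 to compound 3 (0.03 log units; that floor lies within the scatter), so no change beyond the scatter is shown, and the step between compound 1 and compound 2 cannot be read. The true size of both readable steps stays open because the other values are limits: the limit of > 25000 nM in this assay, at which 2 of the 3 values shown sit.

From the compounds shown here alone, whether benzyl or a longer chain ending in a carboxylic acid on this nitrogen would give a number beyond the scatter from compound 3 remains open.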